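The source may report more compounds than this note shows. Statements on the series, on what has been measured and on what is new or still open speak of the compounds shown alone.

Among the measured compounds shown here, compound 3 `CCCCCCSc1cc(C(F)(F)F)ccc1CNC(=O)C(C)c1ccc(NS(C)(=O)=O)c(F)c1` gives 1.8 nM in an assay on CHO cells for antagonist activity at transient receptor potential cation channel subfamily V member 1 (Homo sapiens), read by FLIPR (a lower number here means a stronger inhibitor, a higher number a weaker inhibitor), the lowest of the three numbers so far. Compound 1 `CC(C(=O)NCc1ccc(C(F)(F)F)cc1N1CCCC1)c1ccc(NS(C)(=O)=O)c(F)c1` gives 2.3 nM in this assay, and the two numbers are within the scatter of each other. Compound 2 `CC(C(=O)NCc1ccc(C(F)(F)F)cc1N1CCN(C2CCCCC2)CC1)c1ccc(NS(C)(=O)=O)c(F)c1` gives 13.8 nM in this assay, and a 7.7-fold lower number from compound 2 to compound 3 (0.88 log units; beyond the scatter). Compound 4 `CC(C(=O)NCc1ccc(C(F)(F)F)cc1-c1cccc(Cl)c1)c1ccc(NS(C)(=O)=O)c(F)c1` is not yet measured; it differs from compound 3 in one place: 3-chlorophenyl in place of hexylsulfanyl on an aromatic carbon. For the measured compounds named here, no measured step exchanges hexylsulfanyl for an aromatic group, so the bearing steps are indirect. a 1.3-fold lower number from compound 1 to compound 3 (0.11 log units; within the scatter), which shows that pyrrolidin-1-yl and hexylsulfanyl at this carbon give much the same number. a 6.0-fold higher number from compound 1 to compound 2 (0.78 log units; beyond the scatter), and a 7.7-fold lower number from compound 2 to compound 3 (0.88 log units; beyond the scatter), so the one larger group tried here moved the number modestly upward. On that basis a modest rise is expected for compound 4 in this assay, a 2.8-fold higher number from compound 3 to compound 4 (0.44 log units; beyond the scatter), with wide uncertainty: 3-chlorophenyl is a ring, and none of the groups exchanged so far is one. Compound 4 is estimated at 5 nM in this assay, within 1.5 nM to 20 nM.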

Compound 4, inhibition constant: 1 nM
Estimate against measurement, compound 4: 5.0-fold (0.70 log units) above, and the stated range ends above it.
By their numbers in this assay, from the lowest: compounds 4, 3 and 1 (each within the scatter of the next, the first and the last beyond it); then compound 2.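

In this assay a six-membered aromatic ring of carbon only is accepted on this aromatic carbon: a 1.8-fold lower number from compound 3 to compound 4 (0.26 log units; within the scatter) leaves 3-chlorophenyl not separated from hexylsulfanyl, a group with the same count of heavy atoms but no ring. Against the two cyclic amines the exchange reads differently, with a 2.3-fold lower number from compound 1 to compound 4 (0.36 log units; beyond the scatter) for pyrrolidin-1-yl and a 14-fold lower number from compound 2 to compound 4 (1.14 log units; beyond the scatter) for 4-cyclohexylpiperazin-1-yl, so the ring is the first group here to stand clear of pyrrolidin-1-yl beyond the scatter. No supporting data are available to account for these steps.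

Only one aryl group is shown, so the contribution of the chlorine and of its place on the ring stays open; plain phenyl and 4-chlorophenyl would address this. On these data alone, a shorter chain such as methylsulfanyl, or a carboxylic acid on the ring, also remains open.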